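Ethoxy to propoxy: extending the chain of compound 3

The compounds below may be only part of what the source reports. "The series", "measured", "known", "first", "only" and "open" are said of these compounds alone.

- compound 1 `O=C1Nc2c(ccc(F)c2F)C1(c1ccc(O)cc1)c1ccc(F)cc1` at 8.6 nM
- compound 2 `COc1ccc(C2(c3ccc(O)cc3)C(=O)Nc3c2ccc(F)c3F)cc1` at 2 nM; 2.2 nM; > 1000 nM (3 entries)
- compound 3 `CCOc1ccc(C2(c3ccc(O)cc3)C(=O)Nc3c2ccc(F)c3F)cc1` at 24 nM

In a functional assay on PC-3 cells (Homo sapiens) for cytotoxicity, read by WST assay, with a stated time of 72 h (a higher number here means a weaker inhibitor, a lower number a stronger inhibitor), compound 3 at 24 nM holds the higher of two single numbers, and compound 1 at 8.6 nM lies nearest. Compound 2 has several entries, (the several entries of compound 2 in this assay, 2 nM; 2.2 nM; > 1000 nM (3 entries)), and the last of them is a limit of the assay. Compound 4 `CCCOc1ccc(C2(c3ccc(O)cc3)C(=O)Nc3c2ccc(F)c3F)cc1` carries methyl in place of hydrogen on a saturated chain carbon, two bonds along the chain from an oxygen on an aromatic ring, which reads as ethoxy to propoxy. Among the measured compounds shown here, the only measured step bearing on this is a 2.8-fold higher number from compound 1 to compound 3 (0.45 log units; beyond the scatter), a modest one and a different exchange. A similarly modest rise in the number is therefore expected in this assay, namely a 1.7-fold higher number from compound 3 to compound 4 (0.22 log units; within the scatter), with little confidence in its direction. For compound 4 the estimated value is 40 nM, with an expected range of 12 nM to 150 nM.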

Compound 4, half-maximal inhibitory concentration: > 1000 nM
Compound 4: only a limit was reported (the forecaster's own chance of this, stated with the estimate: 10%); middle value at least 25-fold (1.39 log units) away from the limit.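

In this assay, ethoxy to propoxy at this one chain position gives an at least 41-fold higher number from compound 3 to compound 4 (1.61 log units; beyond the scatter), a large step, whereas the earlier exchange of fluoro for ethoxy gave a modest 2.8-fold higher number from compound 1 to compound 3 (0.45 log units; beyond the scatter). Replacing fluoro with propoxy gives an at least 110-fold higher number from compound 1 to compound 4 (2.06 log units; beyond the scatter), so the series keeps a measured number with ethoxy but not with propoxy. Compound 4 is reported only as a limit, > 1000 nM.

The same limit also appears for compound 2, so its weight as a single entry stays uncertain: the several entries of compound 2 in this assay, 2 nM; 2.2 nM; > 1000 nM (3 entries). As far as these compounds go, whether a butoxy chain or a terminal amine on the chain would return a number remains open.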